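Cytotoxicity notes: thiophene for hydroxyphenyl on the core

The compounds below may be only part of what the source reports. "The series", "measured", "known", "first", "only" and "open" are said of these compounds alone.

Measured compounds:
compound 1 `Cc1cc(-c2ccc(O)cc2)c2ncc(CSCCc3ccccc3)n2c1`, 13.7 ug/mL
compound 2 `Cc1cc(-c2cccs2)cn2c(CSCCc3ccccc3)cnc12`, 32 ug/mL
compound 3 `Cc1cc(-c2ccc(C#N)cc2)cn2c(CSCCc3ccccc3)cnc12`, 10.6 ug/mL

In an ADME assay on HEL cells (Homo sapiens) for cytotoxicity, with a stated time of 3 days (on this read-out lower numbers stand for higher toxicity in this test and higher numbers for lower toxicity in this test), compound 1 stands second highest of the three numbers: its gap to compound 3 lies within the scatter, while compound 2 sits higher, beyond the scatter. Compound 4 `Cc1cc(-c2cccs2)c2ncc(CSCCc3ccccc3)n2c1` is not yet measured; it differs from compound 1 by thiophen-2-yl in place of 4-hydroxyphenyl on an aromatic carbon. For the measured compounds named here, the one measured step that bears on this is the reverse exchange, a 3.0-fold lower number from compound 2 to compound 3 (0.48 log units; beyond the scatter), on a differently arranged core, where the thiophen-2-yl compound gave the higher number. A modest rise is therefore expected, because a 3.0-fold lower number from compound 2 to compound 3 (0.48 log units; beyond the scatter) ran the other way for the same pair of rings; the expected step is a 1.8-fold higher number from compound 1 to compound 4 (0.26 log units; within the scatter). Compound 4 is estimated at 25 ug/mL, within 10 ug/mL to 60 ug/mL.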

Compound 4, half-maximal cytotoxic concentration: > 50 ug/mL
Compound 4 was reported as a limit; the forecaster's own chance of this, stated with the estimate: 5%; middle value at least 2.0-fold (0.30 log units) away from the limit.
By their numbers in this assay, from the lowest: compounds 3 and 1 (each within the scatter of the next); then compound 2. At a limit, above all of these: compound 4.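

In this assay, thiophen-2-yl in place of 4-hydroxyphenyl on the aromatic carbon ortho to a fused ring gives an at least 3.6-fold higher number from compound 1 to compound 4 (0.56 log units; beyond the scatter), the first step measured at this position on this core. Compound 4 reads as a limit of the assay, not a number: the limit of > 50 ug/mL in this assay, at which 1 of the 4 values shown sits.

The compounds shown do not separate the loss of the hydroxyl from the change of ring. Open also is how a plain phenyl, a 4-methoxyphenyl or a 4-aminophenyl at this position would read, and whether the step carries over to the differently arranged core.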